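A few compounds are considered here, and "the series" means these few. Any claim that something is new, unique, unknown or untested is made for them only; others in the source may bear on it.

Measured so far:
compound 1, `CCC(C)CNCCN(C(=O)[C@@H]1C[C@H]1c1ccccc1)c1ccc(-c2ccccc2)cc1` — 4.7 nM
compound 2, `CC[C@H](C)[C@H](N)CN(C(=O)[C@@H]1C[C@H]1c1cncnc1)c1ccc(-c2ccccc2)cc1` — 19000 nM
compound 3, `CCCc1ccc(-c2ccc(N(C[C@@H](N)[C@@H](C)CC)C(=O)[C@@H]3C[C@H]3c3ccccc3)cc2)cc1` — 61 nM

In a functional assay for agonist activity at G protein-coupled receptor 88 (Homo sapiens), read by HTRF and cAMP accumulation (on this read-out lower numbers stand for an effect already at smaller amounts and higher numbers for an effect only at larger amounts of compound), compound 3 gives 61 nM, the second highest of the three numbers. Its nearest neighbour is compound 1, which in this assay gives 4.7 nM, a lower number by a gap beyond the scatter; furthest away is compound 2, which in this assay gives 19000 nM, a higher number by a gap well beyond the scatter. Compound 3 differs from both in more than one place, so no single change can be read from these pairs.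

The next compound, compound 4, `CC[C@H](C)[C@H](N)CN(C(=O)[C@@H]1C[C@H]1c1ccccc1)c1ccc(-c2ccc(C(=O)N(C)C)cc2)cc1`, keeps the amide, the cyclopropane with its phenyl and the aminomethyl chain of compound 3 and differs only on the distal ring:
dimethylcarbamoyl in place of propyl on an aromatic carbon
Among the compounds with values here, no measured pair in the set isolates this change, so the direction of the step rests on the nearest analogues alone. A moderate step is expected, most likely towards a higher number, with the span wide enough to allow no step beyond the scatter: the expected step is a 2.0-fold higher number from compound 3 to compound 4 (0.29 log units; within the scatter). Compound 4 is therefore estimated at 120 nM, within 25 nM to 600 nM.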

Compound 4, half-maximal effective concentration: 980 nM
Estimate against measurement, compound 4: 8.2-fold (0.91 log units) below, and the stated range ends below it.
By their numbers in this assay, from the lowest: compound 1; then compound 3; then compound 4; then compound 2.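

In this assay, within the data shown here, dimethylcarbamoyl in place of propyl on an aromatic carbon gives a 16-fold higher number from compound 3 to compound 4 (1.21 log units; beyond the scatter), the first step that can be read from a single change. The group at this position, para to a large group, therefore bears strongly on the number, and this exchange, which brings in a hydrogen-bond acceptor, is not a neutral one. Nothing measured on these compounds accounts for the size of the step.

Still open, going by these compounds, is whether the carbonyl, the two methyl groups on the nitrogen or the loss of the propyl chain carries the step. A butyl chain, a methoxy group, a primary carboxamide or a carboxylic acid on the same aromatic carbon would help to separate these readings.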